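A few compounds are considered here, and "the series" means these few. Any claim that something is new, unique, unknown or untested is made for them only; others in the source may bear on it.

Measured so far in a functional assay on OVCAR-3 cells (Homo sapiens) for cytotoxicity, read by sulforhodamine B assay; on this read-out higher numbers stand for weaker inhibition of growth and lower numbers for stronger inhibition of growth:
compound 1 `CC1=CC[C@@H]([C@@](C)(O)CCCC(C)(C)NC(=S)N/N=C\c2ccccc2)CC1` gives 12900 nM;
compound 2 `CC1=CC[C@@H]([C@@](C)(O)CCCC(C)(C)NC(=S)N/N=C\c2ccc(C)cc2)CC1` gives 11800 nM;
compound 3 `CC1=CC[C@@H]([C@@](C)(O)CCCC(C)(C)NC(=S)N/N=C\c2cccc(Cl)c2)CC1` gives 26500 nM.

Compound 3 stands at the highest number of the three, with compound 1 nearest at a step of a 2.1-fold higher number from compound 1 to compound 3 (0.31 log units; beyond the scatter) and compound 2 furthest at a 2.2-fold higher number from compound 2 to compound 3 (0.35 log units; beyond the scatter). Between compound 1 and compound 2 the numbers are within the scatter, as the step of a 1.1-fold lower number from compound 1 to compound 2 (0.04 log units; within the scatter) shows.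

Compound 4 `CC1=CC[C@@H]([C@@](C)(O)CCCC(C)(C)NC(=S)N/N=C(/C)c2ccccc2)CC1` differs from compound 3 by a group of 9 heavy atoms (8 carbon, 1 nitrogen; one six-membered aromatic ring of carbon only) in place of a group of 9 heavy atoms (7 carbon, 1 nitrogen, 1 chlorine; one six-membered aromatic ring of carbon only), on an amide-type nitrogen. Within the data shown here, no measured step covers this exchange directly. What bears on it is the step of a 2.1-fold higher number from compound 1 to compound 3 (0.31 log units; beyond the scatter), since the chloro that raised the number in that step leaves here, and the step of a 1.1-fold lower number from compound 1 to compound 2 (0.04 log units; within the scatter), which shows that a methyl on an aromatic carbon changed little. Among the measured compounds shown here, compound 4 carries its methyl on the carbon with the double bond to nitrogen instead, for which there is no measured counterpart. The expectation is therefore that compound 4 falls back toward compound 1, mainly because a 2.1-fold higher number from compound 1 to compound 3 (0.31 log units; beyond the scatter) is undone when the chloro leaves, with added uncertainty from the new methyl. This expected step from compound 3 is a 2.0-fold lower number from compound 3 to compound 4 (0.31 log units; beyond the scatter). Compound 4 is thus estimated at 13000 nM, within a range from 6000 nM to 30000 nM.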

Compound 4, concentration for total growth inhibition: 59500 nM
For compound 4 the middle estimate is 4.6-fold (0.66 log units) below the measured one; the measured number lies above the stated range.
By their numbers in this assay, from the lowest: compounds 2 and 1 (each within the scatter of the next); then compound 3; then compound 4.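

A methyl on the carbon with the double bond to nitrogen does not behave like a methyl on the aromatic ring in this assay: the ring methyl gave a 1.1-fold lower number from compound 1 to compound 2 (0.04 log units; within the scatter), whereas the methyl on the double-bonded carbon gives a 4.6-fold higher number from compound 1 to compound 4 (0.66 log units; beyond the scatter). Moving the methyl from the ring to that carbon gives a 5.0-fold higher number from compound 2 to compound 4 (0.70 log units; beyond the scatter), and losing the chloro at the same time gives a 2.2-fold higher number from compound 3 to compound 4 (0.35 log units; beyond the scatter), so the number rises past the chloro compound instead of falling back, leaving compound 4 with the highest number and thus the weakest inhibition of growth of the four. No measurement is available here that accounts for this rise.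

The compounds shown leave open whether an ethyl or a hydroxymethyl group on the carbon with the double bond to nitrogen would raise the number further, and whether the methyl there would have the same effect alongside a 3-chlorophenyl ring. They also leave open whether these steps would hold with a carbonyl in place of the thiocarbonyl.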